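Swapping an Acetamido for Fluoro on a Shared Core

This account rests on a few compounds, and the source may have more. Where it says the series, first, only, none or still open, it means among the compounds named here.

Three analogues of one core have been tested in a functional assay on NCI-H460 cells (Homo sapiens) for antiproliferative activity, with a stated time of 72 h; a higher number here means a weaker inhibitor, a lower number a stronger inhibitor. Compound 1 `C=CC[C@H]1C[C@]2([C@@H](C)Cc3ccc(OC)c(OC)c3)OCOC2=CC1=O` carries a methoxy on the aromatic ring and gives 260 nM. Compound 2 `C=CC[C@H]1C[C@]2([C@@H](C)Cc3ccc(OC)c(C(=O)NC)c3)OCOC2=CC1=O` carries a methylcarbamoyl and gives 1100 nM. Compound 3 `C=CC[C@H]1C[C@]2([C@@H](C)Cc3ccc(OC)c(NC(C)=O)c3)OCOC2=CC1=O` carries an acetamido and gives 310 nM, the second highest of the three numbers. The known steps are a 1.2-fold higher number from compound 1 to compound 3 (0.08 log units; within the scatter), a 4.2-fold higher number from compound 1 to compound 2 (0.63 log units; beyond the scatter) and a 3.5-fold lower number from compound 2 to compound 3 (0.55 log units; beyond the scatter). Compound 4 `C=CC[C@H]1C[C@]2([C@@H](C)Cc3ccc(OC)c(F)c3)OCOC2=CC1=O` differs from compound 3 by fluoro in place of acetamido on an aromatic carbon. Among the compounds with values here, only one step bears on this change, and it is within the scatter, so compound 4 is expected to sit near compound 3 in this assay, as a 1.0-fold lower number from compound 3 to compound 4 (0.01 log units; within the scatter), because methoxy and acetamido gave a 1.2-fold higher number from compound 1 to compound 3 (0.08 log units; within the scatter). Compound 4 is therefore estimated at 300 nM, within 120 nM to 800 nM.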

Compound 4, half-maximal inhibitory concentration: 90 nM
For compound 4 the middle estimate is 3.3-fold (0.52 log units) above the measured one; the measured number lies below the stated range.
By their numbers in this assay, from the lowest: compound 4; then compounds 1 and 3 (each within the scatter of the next); then compound 2.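

In this assay, this ring position, ortho to a methoxy group, can give a clearly lower number than either earlier group gave there: fluoro gives a 2.9-fold lower number from compound 1 to compound 4 (0.46 log units; beyond the scatter) against methoxy and a 3.4-fold lower number from compound 3 to compound 4 (0.54 log units; beyond the scatter) against acetamido. Against methylcarbamoyl the change is larger, with a 12-fold lower number from compound 2 to compound 4 (1.09 log units; beyond the scatter) in this set, so the group at this position matters more than the earlier compounds showed. No data shown here explain these differences. On these data alone, whether chlorine, a plain hydrogen or an amine at this position would give a number like that of compound 4 remains open.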